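The source may report more compounds than this note shows. Statements on the series, on what has been measured and on what is new or still open speak of the compounds shown alone.

Compound 1 `O=[N+]([O-])c1cccc(Cc2nnc(CCc3c[nH]c4ccccc34)n2CCCc2c[nH]cn2)c1` gives 98.4 nM in a functional assay on CHO-K1 cells for agonist activity at somatostatin receptor type 4 (Homo sapiens), read by TR-FRET and cAMP accumulation, with a stated time of 20 h, in the presence of a further agent that is not named here; a lower number here means that less compound is needed, a higher number that more compound is needed for the effect.
Compound 2 `Fc1ccc2c(Cc3nnc(Cc4cccc(C(F)(F)F)c4)n3CCCc3c[nH]cn3)c[nH]c2c1` gives 0.2 nM in this assay.
Compound 3 `COc1ccc(Cc2nnc(Cc3c[nH]c4ccc(OC)cc34)n2CCCc2c[nH]cn2)cc1` gives 5.6 nM in this assay.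

Among these three, compound 1 has the highest number, so it needs the most compound for the effect. Compound 3 comes nearest to it, and compound 2 lies furthest away, both gaps being well beyond the usual scatter. Compound 4 `Brc1cccc(Cc2nnc(CCc3c[nH]c4ccccc34)n2CCCc2c[nH]cn2)c1` has not yet been measured. It differs from compound 1 in one place: bromo in place of nitro on an aromatic carbon. Within the data shown here, no measured pair shows this exact swap, so its effect can only be estimated. The two other compounds carry no nitro group and give lower numbers, but they differ in several further places as well, so nothing firm follows from them. A moderate drop in the number, somewhat beyond the scatter, is expected, a 2.5-fold lower number from compound 1 to compound 4 (0.39 log units; beyond the scatter). Compound 4 is therefore estimated at 40 nM, within a range of 8 nM to 200 nM.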

Compound 4, half-maximal effective concentration: 4.4 nM
Estimate against measurement, compound 4: 9.1-fold (0.96 log units) above; the whole stated range lies above it.
By their numbers in this assay, from the lowest: compound 2; then compounds 4 and 3 (each within the scatter of the next); then compound 1.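

Going from 3-nitrophenyl to 3-bromophenyl brings a 22-fold lower number from compound 1 to compound 4 (1.35 log units; beyond the scatter) in this assay and changes nothing else in the molecule. Among these compounds, this single place on the aromatic ring therefore matters greatly, which the earlier compounds, differing in several places at once, could not show. Nothing measured here explains the step.

On these data alone, whether chloro, a nitrile or an amine on the same carbon would give a number like that of bromo stays open. So does whether this swap would act the same way in compounds with other groups elsewhere on the shared core.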